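This account rests on a few compounds, and the source may have more. Where it says the series, first, only, none or still open, it means among the compounds named here.

In a functional assay on K562 cells (Homo sapiens) for inhibition, read by trypan blue exclusion, with a stated time of 72 h (a higher number here means a weaker inhibitor, a lower number a stronger inhibitor), two compounds sharing one core have been measured so far. Compound 1 (`Cn1c(=O)c(S(=O)(=O)c2ccc(F)cc2)cc2cnc(Nc3ccc4[nH]ccc4c3)nc21`) gives 200 nM, and compound 2 (`Cn1c(=O)c(S(=O)(=O)c2ccc(O)cc2)cc2cnc(Nc3ccc4[nH]ccc4c3)nc21`) gives 100 nM. These two values lie within the scatter of each other, so compound 2 stands level with compound 1 on the numbers available.

Compound 3 (`Cn1c(=O)c(S(=O)(=O)c2ccc(N)cc2F)cc2cnc(Nc3ccc4[nH]ccc4c3)nc21`) has 4-amino-2-fluorophenyl in place of 4-hydroxyphenyl on a sulfonyl sulfur. Going by the values given here, only one measured step bears on this change, and it too alters a group on the aromatic ring carried by the sulfonyl sulfur: hydroxy in place of fluoro gave a 2.0-fold lower number from compound 1 to compound 2 (0.30 log units; within the scatter). Among the compounds with values here, no measured compound carries the amino group, so the data offer only this indirect guide. On that basis, no step beyond the scatter is expected in this assay, and no direction can be favoured with confidence. The estimate amounts to a 1.2-fold higher number from compound 2 to compound 3 (0.08 log units; within the scatter), an expected step that remains small. For compound 3 the estimated value is 120 nM, with an expected range from 40 nM to 350 nM.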

Compound 3, half-maximal inhibitory concentration: 1500 nM
Estimate against measurement, compound 3: 13-fold (1.10 log units) below, and the stated range ends below it.
By their numbers in this assay, from the lowest: compounds 2 and 1 (each within the scatter of the next); then compound 3.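

In this assay, the aromatic ring on the sulfonyl sulfur proves able to shift the number well beyond the scatter: 4-amino-2-fluorophenyl in place of 4-hydroxyphenyl gives a large step (a 15-fold higher number from compound 2 to compound 3 (1.18 log units; beyond the scatter)), and 4-amino-2-fluorophenyl in place of 4-fluorophenyl gives a modest one (a 7.5-fold higher number from compound 1 to compound 3 (0.88 log units; beyond the scatter)). The earlier pair, carrying 4-fluorophenyl and 4-hydroxyphenyl, stood within the scatter of each other, so only compound 3 shows that this position does not tolerate every change, and it now stands as the weakest of the three, with both of its steps beyond the scatter. No evidence on hand accounts for this loss.

The new group differs from both earlier ones in more than one substituent, so the compounds shown leave open whether the amino group or the fluoro group drives the step, which a ring carrying only one of the two could separate. Also open, from the compounds shown here alone, is how other groups on this ring, such as a methoxy group or a carboxylic acid, would read in this assay.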